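The compounds below may be only part of what the source reports. "The series", "measured", "known", "first", "only" and "open" are said of these compounds alone.

Compound 1 `CCC(=O)N1CCc2nc(C#Cc3ccccc3)sc2C1` gives 38 nM in an assay on HEK293 cells for negative allosteric modulation of metabotropic glutamate receptor 5 (Homo sapiens), read by FLIPR, with a stated time of 1 h; a lower number here means a stronger inhibitor, a higher number a weaker inhibitor.
Compound 2 `CC1CC1C(=O)N1CCc2nc(C#Cc3ccccc3)sc2C1` gives only a limit, > 10000 nM, in this assay.
Compound 3 `O=C(C1CCCC1)N1CCc2nc(C#Cc3ccccc3)sc2C1` gives only a limit, > 10000 nM, in this assay.

Compound 3 thus stands at the edge of what this assay reports, and its value is a limit rather than a number; the same holds for compound 2, as the limit of > 10000 nM in this assay, at which 2 of the 3 values shown sit, records. The step of an at least 260-fold higher number from compound 1 to compound 3 (2.42 log units; beyond the scatter) is large, and the step of an at least 260-fold higher number from compound 1 to compound 2 (2.42 log units; beyond the scatter) is of the same kind, so both ring groups on the carbonyl carbon sit far from compound 1. The step that the two limits leave unreadable from compound 2 to compound 3 cannot be read, since both ends are limits.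

Compound 4 `CC1CCC(C(=O)N2CCc3nc(C#Cc4ccccc4)sc3C2)CC1` is not yet measured. It carries 4-methylcyclohexyl in place of cyclopentyl on a carbonyl carbon. Both measured steps that bear on this place, an at least 260-fold higher number from compound 1 to compound 2 (2.42 log units; beyond the scatter) and an at least 260-fold higher number from compound 1 to compound 3 (2.42 log units; beyond the scatter), moved a ring group far toward the limit, and compound 4 carries a larger ring of the same sort. Compound 4 is therefore expected to stay at or beyond the limit, with the step that the limit leaves unreadable from compound 3 to compound 4 expected to be unreadable. The estimate for compound 4 in this assay is 15000 nM, within 3000 nM to 60000 nM.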

Compound 4, half-maximal inhibitory concentration: > 10000 nM
Compound 4: a limit, no number; the forecaster's own chance of this, stated with the estimate: 80%; the middle value lies beyond the limit too.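

In this assay, compound 4 gives > 10000 nM, which is a limit and not a number. The step of an at least 260-fold higher number from compound 1 to compound 4 (2.42 log units; beyond the scatter) is large, so a six-membered ring now joins the 2-methylcyclopropyl of compound 2 and the cyclopentyl of compound 3 among the ring groups far from compound 1. The steps among compound 2, compound 3 and compound 4 cannot be read, since both ends of each are limits, so these ring groups cannot be ranked, and the record now stands as: the limit of > 10000 nM in this assay, at which 3 of the 4 values shown sit.

Going by these compounds, only the ethyl of compound 1 gives a number here, so it remains open whether a longer chain such as butyl, or an unsubstituted cyclopropyl, would also give one. On these data alone, it is equally open how an amine carried on the ring of compound 4 would read.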